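The source may report more compounds than this note shows. Statements on the series, on what has been measured and on what is new or still open speak of the compounds shown alone.

compound 1 `S=C(N/N=C/c1cccs1)Nc1ccccc1` gives 74700 nM
compound 2 `S=C(N/N=C/c1cccs1)Nc1cccnc1` gives 26000 nM

In a functional assay on U-251 cells (Homo sapiens) for inhibition, read by sulforhodamine B assay, with a stated time of 48 h (a lower number here means a stronger inhibitor of growth, a higher number a weaker inhibitor of growth), compound 1 holds the higher of the two numbers, and compound 2 lies lower by a gap beyond the scatter. Compound 3 `COc1ccc(NC(=S)N/N=C/c2cccs2)cc1` differs from compound 1 by methoxy in place of hydrogen on an aromatic carbon, para to a large group. Among the measured compounds shown here, no measured step covers this change, so the expectation stays modest: a small downward move, near the edge of the scatter. The expected step is a 1.9-fold lower number from compound 1 to compound 3 (0.27 log units; within the scatter). The estimate for compound 3 is 40000 nM, with an expected range from 13000 nM to 100000 nM.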

Compound 3, concentration for 50% growth inhibition: > 100000 nM
Compound 3: a limit, no number (the forecaster's own chance of this, stated with the estimate: 10%); middle value at least 2.5-fold (0.39 log units) away from the limit.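

In this assay compound 3 carries a limit of the assay and not a number: the limit of > 100000 nM in this assay, at which 1 of the 3 values shown sits.

Among the compounds shown here, this gives the only reading at this place, para to a large group, and methoxy in place of hydrogen there brings no gain in growth inhibition, with an at least 1.3-fold higher number from compound 1 to compound 3 (0.12 log units; that floor lies within the scatter). Only the floor of that step is known, so its true size stays undefined.

Going by these compounds, whether fluoro, hydroxyl or an amine at the same place would lower the number remains open. Also open, on these data alone, is whether methoxy would act alike on the ring of compound 2.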